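Swapping an aryl amide for a branched alkyl chain

The compounds below may be only part of what the source reports. "The series", "measured", "known", "first", "only" and "open" are said of these compounds alone.

Three compounds with a shared core have numbers in a functional assay on U2OS cells for antagonist activity at proto-oncogene Wnt-3 (Homo sapiens), read by a luciferase reporter, with a stated time of 18 h; a higher number here means that more compound is needed for the effect, a lower number that less compound is needed. Compound 1 `CN(C)CC(=O)N1CCC(NS(=O)(=O)c2cc(S(=O)(=O)c3ccccc3)ccc2C(F)(F)F)CC1` gives 280 nM in this assay, and compound 2 `CN(C)CC(=O)N1CCC[C@H]1C(=O)N1CCC(NS(=O)(=O)c2cc(S(=O)(=O)c3ccccc3)ccc2C(F)(F)F)CC1` gives 310 nM, a change of a 1.1-fold higher number from compound 1 to compound 2 (0.04 log units; within the scatter). Compound 3 `CN(C)c1ccc(C(=O)N2CCC[C@H]2C(=O)N2CCC(NS(=O)(=O)c3cc(S(=O)(=O)c4ccccc4)ccc3C(F)(F)F)CC2)cc1` gives 830 nM in this assay, the highest of the three numbers, and the step is a 2.7-fold higher number from compound 2 to compound 3 (0.43 log units; beyond the scatter). Compound 4 `CC(C)(C)CCN1CCC[C@H]1C(=O)N1CCC(NS(=O)(=O)c2cc(S(=O)(=O)c3ccccc3)ccc2C(F)(F)F)CC1` is not yet measured. It differs from compound 3 in one place: 3,3-dimethylbutyl in place of (4-(dimethylamino)phenyl)carbonyl on an amine nitrogen in a ring. Going by the values given here, of the measured steps, the one from compound 2 to compound 3 bears most directly on this change, since it altered the same group on the same ring nitrogen and produced a modest rise; the step from compound 1 to compound 2 shows that building out this part of the molecule need not move the number at all. Compound 4 undoes the aryl amide and is therefore expected to land between the numbers of compound 2 and compound 3, with the step of a 1.8-fold lower number from compound 3 to compound 4 (0.27 log units; within the scatter) estimated as a modest fall. The estimate for compound 4 in this assay is 450 nM, within a range of 150 nM to 1400 nM.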

Compound 4, half-maximal effective concentration: 450 nM
Compound 4: the middle estimate sits on the measured number at the digits printed; the range from low to high includes it.
By their numbers in this assay, from the lowest: compounds 1, 2, 4 and 3 (each within the scatter of the next, the first and the last beyond it).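

In this assay, the amine nitrogen in the ring tolerates a 3,3-dimethylbutyl chain, which has no ring, no nitrogen and no oxygen: the result is a 1.8-fold lower number from compound 3 to compound 4 (0.27 log units; within the scatter) and a 1.5-fold higher number from compound 2 to compound 4 (0.16 log units; within the scatter). A carbonyl on this nitrogen is therefore not needed to keep the number in this range, and the full side chain of compound 4 also stays close to the smaller group of compound 1, with a 1.6-fold higher number from compound 1 to compound 4 (0.21 log units; within the scatter). No measurement available here accounts for these small steps.

As far as these compounds go, whether the unsubstituted ring nitrogen, a shorter alkyl chain or a benzyl group would behave in the same way remains open. So does the effect of a terminal amine or a carboxylic acid on the 3,3-dimethylbutyl chain's carbon skeleton.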